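The source may hold more compounds than are shown below. What is called first, only, known or untested is meant among the compounds shown, and "the series" means these compounds.

Measured compounds:
- compound 2 `COC(=O)/C=C/c1ccncc1-c1ccc2ccccc2c1` — 40.6 nM
- compound 1 `CC(C)[C@@H](NC(=O)/C=C/c1ccncc1-c1ccc2ccccc2c1)C(=O)O` — "not determined" (no result reported)

Three compounds share one core. Within the data shown here, in an assay on a protein complex for inhibition of CDK8/Cyclin C (Homo sapiens), with a stated time of 1 h (a higher number here means a weaker inhibitor, a lower number a stronger inhibitor), compound 2 gives 40.6 nM, the only number in hand; for compound 1 the entry reads "not determined" (no result reported), so compound 2 stands alone as the sole reference. Compound 3 `O=C(/C=C/c1ccncc1-c1ccc2ccccc2c1)NC1CC1` is not yet measured in this assay. It differs from compound 2 in one place: cyclopropylamino in place of methoxy on a carbonyl carbon. The change, cut one bond further out, reads methoxycarbonyl to cyclopropylcarbamoyl, on a carbonyl carbon whose other neighbour is a double-bonded chain carbon.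

Among the measured compounds shown here, no step between measured compounds is available, so the size of the change cannot be read from the data. The expectation is that the step of a 1.4-fold lower number from compound 2 to compound 3 (0.13 log units; within the scatter) stays within the scatter, with a slight lean toward a stronger inhibitor. Compound 3 is estimated at 30 nM in this assay, with a range from 10 nM to 100 nM.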

Compound 3, half-maximal inhibitory concentration: 40.1 nM
Compound 3: middle estimate off by 1.3-fold (0.13 log units), on the low side, within the range that was stated.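

In this assay, cyclopropylamino in place of methoxy on a carbonyl carbon gives a 1.0-fold lower number from compound 2 to compound 3 (0.01 log units; within the scatter). This first comparison at the position shows that methoxycarbonyl can give way to cyclopropylcarbamoyl, bringing in a three-membered ring and a hydrogen-bond donor, with no difference between compound 2 and compound 3 beyond the scatter. No measurement bears on why the two compounds read alike.

A single pair cannot show whether this holds for other groups on the same carbonyl carbon, such as a dimethylamino group, a morpholine ring or a longer chain on the amide nitrogen. It also leaves open whether a free carboxylic acid at this carbonyl carbon would fit the same picture.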